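The compounds below may be only part of what the source reports. "The series", "measured", "known", "first", "only" and "open" are said of these compounds alone.

Compound 1 `CC1=CC[C@@H]([C@@](C)(O)CCCC(C)(C)NC(=S)N/N=C\c2ccc(C)cc2)CC1`: in a functional assay on UACC-62 cells (Homo sapiens) for cytotoxicity, read by sulforhodamine B assay (on this read-out higher numbers stand for weaker inhibition of growth and lower numbers for stronger inhibition of growth), compound 1 gives 11600 nM. Compound 2 `CC1=CC[C@@H]([C@@](C)(O)CCCC(C)(C)NC(=S)N/N=C\c2ccc(N(C)C)cc2)CC1`: in this assay compound 2 reaches only the limit of > 100000 nM.

Among the compounds with values here, compound 1 thus holds the only numeric value shown; the other result is a limit (the limit of > 100000 nM in this assay, at which 1 of the 2 values shown sits). Compound 3 `CC1=CC[C@@H]([C@@](C)(O)CCCC(C)(C)NC(=S)N/N=C\c2ccccc2[N+](=O)[O-])CC1` differs from compound 1 by 2-nitrophenyl in place of 4-methylphenyl on a carbon with a double bond to nitrogen. Within the data shown here, the single measured step, an at least 8.6-fold higher number from compound 1 to compound 2 (0.93 log units; beyond the scatter), changes a different group on the aromatic ring and so bears only loosely on this exchange; a small weakening, or none beyond the scatter, is expected. Compound 3 is therefore expected at an estimated 20000 nM (range 7000 nM to 60000 nM), a step of a 1.7-fold higher number from compound 1 to compound 3 (0.24 log units; within the scatter) expected in this assay.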

Compound 3, concentration for 50% growth inhibition: 6050 nM
Compound 3: the middle estimate sits 3.3-fold (0.52 log units) above what was measured, and the stated range ends above it.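

Exchanging 4-methylphenyl for 2-nitrophenyl on the carbon with a double bond to nitrogen gives a 1.9-fold lower number from compound 1 to compound 3 (0.28 log units; within the scatter) in this assay, so this aromatic ring tolerates the nitro group without a change beyond the scatter. Against 4-(dimethylamino)phenyl, the same group gives an at least 16-fold lower number from compound 2 to compound 3 (1.21 log units; beyond the scatter), which shows that the loss in compound 2 does not extend to every substituted phenyl ring here. The result for compound 2 is a limit, so this step has no exact size: the limit of > 100000 nM in this assay, at which 1 of the 3 values shown sits.

From the compounds shown here alone, whether a phenyl ring carrying a carboxylic acid or a hydroxyl group would behave like compound 3 or like compound 2 remains open.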